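The source may report more compounds than this note shows. Statements on the series, on what has been measured and on what is new or still open speak of the compounds shown alone.

The series is built on one shared core, carried by compound 1 `CNC(=O)CSc1nc2ccc(NC(=O)c3ccc([N+](=O)[O-])cc3)cc2s1`, compound 2 `O=C(CSc1nc2ccc(NC(=O)c3ccc([N+](=O)[O-])cc3)cc2s1)NCc1ccccc1`, compound 3 `CNC(=O)CSc1nc2ccc(NC(=O)c3ccc(Cl)cc3)cc2s1` and compound 4 `O=C(CSc1nc2ccc(NC(=O)c3ccc(Cl)cc3)cc2s1)NCc1ccccc1`. In a functional assay on MCF7 cells (Homo sapiens) for cytotoxicity, read by MTT assay, with a stated time of 48 h (on this read-out lower numbers stand for stronger inhibition and higher numbers for weaker inhibition), compound 1 gives > 100000 nM, which is a limit of the assay rather than a number. In this assay compound 2 likewise gives > 100000 nM, again a limit. In this assay, among the measured compounds shown here, compound 3 gives 29400 nM, the only number among the three measured compounds. The cores of compound 1 and compound 3 differ by chloro in place of nitro on an aromatic carbon; that change gives an at least 3.4-fold lower number from compound 1 to compound 3 (0.53 log units; beyond the scatter). The change made from compound 1 to compound 2 is phenyl in place of hydrogen on a saturated chain carbon bound to an amide-type nitrogen, and it gives a step that the two limits leave unreadable from compound 1 to compound 2; the step stays unreadable because the limit of > 100000 nM in this assay, at which 2 of the 3 values shown sit, holds both of its ends. The same change, (phenyl in place of hydrogen on a saturated chain carbon bound to an amide-type nitrogen), is made from compound 3 to compound 4. The measured instance of this change shows nothing either way, so the expectation for compound 4 rests on the value of compound 3, 29400 nM. A step of a 1.0-fold higher number from compound 3 to compound 4 (0.01 log units; within the scatter) is expected in this assay. Compound 4 is accordingly expected at 30000 nM, with a range from 10000 nM to 100000 nM.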

Compound 4, half-maximal inhibitory concentration: 25900 nM
Compound 4: middle estimate off by 1.2-fold (0.06 log units), on the high side; low and high end bracket the measured number.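

Notes on carrying the changes: in this assay, chloro in place of nitro on an aromatic carbon gives a lower number on a second core as well, with an at least 3.8-fold lower number from compound 2 to compound 4 (0.58 log units; beyond the scatter), and the two instances compare as follows: the same change on two cores in this assay, an at least 3.4-fold lower number (0.53 log units; beyond the scatter) from compound 1 to compound 3 and an at least 3.8-fold lower number (0.58 log units; beyond the scatter) from compound 2 to compound 4; the limit leaves it open whether they differ So the direction of this change holds on both cores shown, but its size on either core is not fixed. Phenyl in place of hydrogen on a saturated chain carbon bound to an amide-type nitrogen gives a 1.1-fold lower number from compound 3 to compound 4 (0.06 log units; within the scatter), while its step on the nitro-bearing core cannot be read, so whether this near-absence of effect carries over to that core is not shown, because of this: the limit of > 100000 nM in this assay, at which 2 of the 4 values shown sit.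

Still open, on these data alone, is how groups other than chloro and nitro on that aromatic carbon, such as bromo or methoxy, would read in this assay. Also open, as far as these compounds go, is whether a carboxylic acid or a longer chain in place of the methylcarbamoyl or benzylcarbamoyl group would shift the number on the chloro-bearing core.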